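A few compounds are considered here, and "the series" means these few. Any claim that something is new, unique, unknown or untested is made for them only; others in the source may bear on it.

Compound 1 `NCc1ccccc1CN(Cc1nc2ccccc2[nH]1)C1CCCc2cccnc21`: 50 nM
Compound 2 `NC/C=C/CN(Cc1nc2ccccc2[nH]1)C1CCCc2cccnc21`: 160 nM
Compound 3 `NCC#CCN(Cc1nc2ccccc2[nH]1)C1CCCc2cccnc21`: 973 nM

Among the three numbers from a functional assay on CEM-CCRF cells for antagonist activity at C-X-C chemokine receptor type 4 (Homo sapiens), read by calcium flux (a higher number here means a weaker inhibitor, a lower number a stronger inhibitor), compound 2 stands second highest: compound 1 lies lower by a 3.2-fold higher number from compound 1 to compound 2 (0.51 log units; beyond the scatter), compound 3 higher by a 6.1-fold higher number from compound 2 to compound 3 (0.78 log units; beyond the scatter). Compound 4 `CN(C)CCCCN(Cc1nc2ccccc2[nH]1)C1CCCc2cccnc21` differs from compound 2 by 3-(dimethylamino)propyl in place of 3-aminoprop-1-en-1-yl on a saturated chain carbon bound to an amine nitrogen. Among the compounds with values here, no measured step exchanges the chain for a saturated one, so the bearing evidence is indirect: both chain changes seen so far, a 3.2-fold higher number from compound 1 to compound 2 (0.51 log units; beyond the scatter) and a 6.1-fold higher number from compound 2 to compound 3 (0.78 log units; beyond the scatter), weakened inhibition, and end to end they amount to a 19-fold higher number from compound 1 to compound 3 (1.29 log units; beyond the scatter). On that basis a modest move toward a higher number is expected for compound 4 in this assay, a 2.5-fold higher number from compound 2 to compound 4 (0.40 log units; beyond the scatter), nothing in the series arguing for a gain. Compound 4 is estimated at 400 nM, range 120 nM to 1500 nM.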

Compound 4, half-maximal inhibitory concentration: 87 nM
Compound 4: middle estimate off by 4.6-fold (0.66 log units), on the high side; measured number below the stated range.
By their numbers in this assay, from the lowest: compounds 1, 4 and 2 (each within the scatter of the next, the first and the last beyond it); then compound 3.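

In this assay 3-(dimethylamino)propyl is tolerated on a saturated chain carbon bound to an amine nitrogen: a 1.8-fold lower number from compound 2 to compound 4 (0.26 log units; within the scatter) and a 1.7-fold higher number from compound 1 to compound 4 (0.24 log units; within the scatter) both stay within the scatter, so this position needs neither a ring nor a double bond in the group. Only the group of compound 3 stands apart, with an 11-fold lower number from compound 3 to compound 4 (1.05 log units; beyond the scatter) as the step back. No evidence on the cause of these steps is available.

Compound 4 changes both the chain and the amine at once, so the two effects cannot be separated. Open, as far as these compounds go, is how 3-aminopropyl, a longer chain ending in dimethylamino, or a piperidine end would compare.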